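Working notes on the step from compound 3 to compound 4

The source may report more compounds than this note shows. Statements on the series, on what has been measured and on what is new or still open speak of the compounds shown alone.

Measured so far in a functional assay on MDA-MB-231 cells (Homo sapiens) for inhibition, read by CCK-8 assay, with a stated time of 48 h; on this read-out lower numbers stand for stronger inhibition of growth and higher numbers for weaker inhibition of growth:
compound 1, `Cc1ccccc1Nc1nc(Nc2ccc(N3CCN(C)CC3)cn2)ncc1Cl`: 7470 nM
compound 2, `CN1CCN(c2ccc(Nc3ncc(Cl)c(Nc4ccccc4)n3)nc2)CC1`: 37400 nM
compound 3, `CN1CCN(c2ccc(Nc3ncc(Cl)c(NCc4ccc(C(F)(F)F)cc4)n3)nc2)CC1`: 19100 nM

Compound 3 holds the second highest of the three numbers; its nearest neighbour is compound 2, a 2.0-fold lower number from compound 2 to compound 3 (0.29 log units; within the scatter), and its furthest is compound 1, a 2.6-fold higher number from compound 1 to compound 3 (0.41 log units; beyond the scatter).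

Compound 4, `Cc1ccc(CNc2nc(Nc3ccc(N4CCN(C)CC4)cn3)ncc2Cl)cc1`, differs from compound 3 by methyl in place of trifluoromethyl on an aromatic carbon.

Within the data shown here, no measured step touches the substituent on the benzyl ring. The two steps that reach compound 3 both change the whole group on the ring nitrogen, a 2.6-fold higher number from compound 1 to compound 3 (0.41 log units; beyond the scatter) and a 2.0-fold lower number from compound 2 to compound 3 (0.29 log units; within the scatter), and the third, a 5.0-fold higher number from compound 1 to compound 2 (0.70 log units; beyond the scatter), removes a methyl from a ring attached directly to the nitrogen. None of them tells how the ring of the benzyl group answers to a change of this kind, so no step beyond the scatter is expected in this assay in either direction.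

Compound 4 is therefore expected near 20000 nM, in the range 7000 nM to 55000 nM, the expected step being a 1.0-fold higher number from compound 3 to compound 4 (0.02 log units; within the scatter).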

Compound 4, concentration for 50% growth inhibition: 18600 nM
Estimate against measurement, compound 4: 1.1-fold (0.03 log units) above; measured number inside the range.
By their numbers in this assay, from the lowest: compound 1; then compounds 4, 3 and 2 (each within the scatter of the next).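

In this assay, among these compounds, the step from trifluoromethyl to methyl gives the first reading on the benzyl ring, at the place para to a large group (a 1.0-fold lower number from compound 3 to compound 4 (0.01 log units; within the scatter)), and the exchange of four heavy atoms for one produces no step beyond the scatter there. The 4-methylbenzyl group gives the same picture as the 4-(trifluoromethyl)benzyl group against the two anilines: it stays within the scatter of the phenyl group (a 2.0-fold lower number from compound 2 to compound 4 (0.30 log units; within the scatter)), and the 2-methylphenyl group of compound 1 keeps a modest gap beyond it (a 2.5-fold higher number from compound 1 to compound 4 (0.40 log units; beyond the scatter)). Nothing at hand explains these readings.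

On these data alone, only two substituents at this place have been compared, both without hydrogen-bond donors or acceptors, so an amine or a carboxylic acid there remains open. As far as these compounds go, a longer chain between the nitrogen and the ring also remains open.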